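Removing the Methoxy Group from a Cyclic Amide Core

A few compounds are considered here, and "the series" means these few. Any claim that something is new, unique, unknown or untested is made for them only; others in the source may bear on it.

Measured compounds:
compound 1 `COc1ccc(C23CCC(=O)N2CCCO3)cc1` gives < 150 mg/kg
compound 2 `O=C(CCC(=O)c1ccc(Cl)c(Cl)c1)NCCCO` gives 300 mg/kg
compound 3 `O=C(CCC(=O)c1ccc(F)cc1)NCCCO` gives 300 mg/kg

In a functional assay on the whole organism (Central nervous system) for activation, with Mus musculus as the target (a higher number here means that more compound is needed for the effect, a lower number that less compound is needed), compound 1 gives < 150 mg/kg, which is a limit of the assay rather than a measured number: the limit of < 150 mg/kg in this assay, at which 1 of the 3 values shown sits. In this assay, among the compounds with values here, compound 2 gives 300 mg/kg and compound 3 gives 300 mg/kg; these two values lie within the scatter of each other, and no step between any pair of measured compounds is known. Compound 4 `O=C1CCC2(c3ccccc3)OCCCN12` differs from compound 1 by hydrogen in place of methoxy on an aromatic carbon. With only a limit for compound 1, the step that the limit leaves unreadable from compound 1 to compound 4 is expected to be small, not beyond the usual scatter in either direction. Compound 4 is therefore expected to give about 120 mg/kg, with a range from 40 mg/kg to 350 mg/kg, in this assay.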

Compound 4, dose for half-maximal effect: 37.5 mg/kg
Compound 4: middle estimate off by 3.2-fold (0.51 log units), on the high side; measured number outside the range, below it.
By their numbers in this assay, from the lowest: compound 4; then compounds 2 and 3 (each within the scatter of the next).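

No step from compound 1 to compound 4 can be read, because compound 1 carries only a limit of the assay and not a number: the limit of < 150 mg/kg in this assay, at which 1 of the 4 values shown sits.

The compounds shown leave open how far, and in which direction, hydrogen in place of methoxy shifts the dose needed.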